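Fluoro for methyl on the thioether aryl of compound 3

A few compounds are considered here, and "the series" means these few. Any claim that something is new, unique, unknown or untested is made for them only; others in the source may bear on it.

Measured compounds:
Compound 1 `COc1ccc(SCc2ccc(/C=C/C(=O)Nc3ccccc3N)cc2)cc1OC`: 46.4%
Compound 2 `Nc1ccccc1NC(=O)c1ccc(CSc2ccc(C(F)(F)F)cn2)cc1`: 5.34%
Compound 3 `Cc1ccc(SCc2ccc(C(=O)Nc3ccccc3N)cc2)cc1`: 67%

In a functional assay on A-375 cells (Homo sapiens) for inhibition, read by CCK-8 assay, with a stated time of 72 h, tested at 8 uM (on this read-out higher numbers stand for more inhibition of growth at the one concentration tested and lower numbers for less inhibition of growth), compound 3 gives the highest of the three numbers; compound 1 lies lower by a margin beyond the scatter, and compound 2 lies furthest below. Compound 4 `Nc1ccccc1NC(=O)c1ccc(CSc2ccc(F)cc2)cc1` is not yet measured in this assay. It differs from compound 3 in one place: fluoro in place of methyl on an aromatic carbon. For the measured compounds named here, no step between measured compounds shows how this change acts; the single-point growth inhibition of compound 3 is the only direct reference. The step is expected to be small, downward if anything, and not clearly beyond the scatter. For compound 4 an estimated step of a number 9 percentage points lower from compound 3 to compound 4 (within the scatter) is expected. Compound 4 is therefore expected to give about 58% in this assay, within a range from 35% to 78%.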

Compound 4, percent growth inhibition at one concentration: 54.3%
Estimate against measurement, compound 4: 3.7 percentage points above, and the stated range covers the measured number.
By their numbers in this assay, from the lowest: compound 2; then compounds 1 and 4 (each within the scatter of the next); then compound 3.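

For the compounds shown here, the change of 4-methylphenyl to 4-fluorophenyl gives the first direct reading at this position: in this assay it brings a number 12.7 percentage points lower from compound 3 to compound 4 (beyond the scatter). The position therefore responds to a one-atom exchange, yet compound 4 keeps a substantial part of the growth inhibition seen with compound 3. Nothing measured here accounts for this step.

Going by these compounds, it remains open how chloro or an amine at the same place would compare with methyl and fluoro. On these data alone, it also remains open whether fluoro in place of methyl would act in the same way on another core.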